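Chloro to Methoxy on the Benzyl Ring

The source may hold more compounds than are shown below. What is called first, only, known or untested is meant among the compounds shown, and "the series" means these compounds.

Compound 1, `COc1cccc(OC)c1OCCNCCOc1ccccc1OCc1cccc(Cl)c1`, gives 7.93 in a functional assay on spleen for antagonist activity at Alpha-1B adrenergic receptor (Rattus norvegicus); on this read-out higher numbers stand for higher potency (the scale is a negative logarithm) and lower numbers for lower potency. Compound 2, `COc1cccc(OC)c1OCCNCCOc1ccccc1OCc1cccc(C)c1`, gives 8.2. Compound 3, `COc1ccccc1COc1ccccc1OCCNCCOc1c(OC)cccc1OC`, gives 8.13.

Compound 1 carries the lowest of these three numbers, yet both gaps are small: a number 0.20 log units higher from compound 1 to compound 3 (within the scatter), and a number 0.27 log units higher from compound 1 to compound 2 (within the scatter). Compound 4, `COc1cccc(COc2ccccc2OCCNCCOc2c(OC)cccc2OC)c1`, differs from compound 1 by methoxy in place of chloro on an aromatic carbon. For the measured compounds named here, two measured steps bear on it. Exchanging the chloro for another small group at the same aromatic carbon gave a number 0.27 log units higher from compound 1 to compound 2 (within the scatter), and exchanging the whole 3-chlorophenyl for 2-methoxyphenyl gave a number 0.20 log units higher from compound 1 to compound 3 (within the scatter). Neither left the scatter, so no step beyond the scatter is expected in this assay for compound 4, with the estimate a number 0.17 log units higher from compound 1 to compound 4 (within the scatter). Compound 4 is therefore estimated at 8.1, between 7.7 and 8.5.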

Compound 4, negative logarithm of the antagonist equilibrium constant: 8.31
Estimate against measurement, compound 4: 0.21 log units below, and the stated range covers the measured number.
By their numbers in this assay, from the lowest: compounds 1, 3, 2 and 4 (each within the scatter of the next, the first and the last beyond it).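

Methoxy in place of chloro on this aromatic carbon, meta to a large group, is the first change at this site to leave the scatter in this assay (a number 0.38 log units higher from compound 1 to compound 4 (beyond the scatter)). Compound 4 separates from compound 1 alone, since the 3-methoxyphenyl in place of 2-methoxyphenyl stays within it (a number 0.18 log units higher from compound 3 to compound 4 (within the scatter)). Methoxy in place of methyl does the same (a number 0.11 log units higher from compound 2 to compound 4 (within the scatter)).

On these data alone, how an ethoxy or a hydroxy group on this aromatic carbon would read remains open. Nothing shown here gives a reason for the gain over compound 1.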